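Amide nitrogen change in the shared-core ether series

This account rests on a few compounds, and the source may have more. Where it says the series, first, only, none or still open, it means among the compounds named here.

Compound 2 `COc1ccc2nc(C)cc(OCC(=O)Nc3ccc(C)cc3)c2c1` gives 41500 nM in an ADME assay on HepG2 cells (Homo sapiens) for cytotoxicity, read by trypan blue exclusion, with a stated time of 48 h, in the presence of a further agent that is not named here; a lower number here means that less compound is tolerated, a higher number that more compound is tolerated. Within the data shown here, that is the only actual number in this assay; the other entry is a limit. Compound 1 `COc1ccc(NC(=O)COc2cc(C)nc3ccc(OC)cc23)cc1` sits at the assay limit of > 142000 nM in this assay. Among the measured compounds shown here, the single measured step, an at least 3.4-fold lower number from compound 1 to compound 2 (0.53 log units; beyond the scatter), rests on the limit of > 142000 nM in this assay, at which 1 of the 2 values shown sits, and concerns a substituent on the aromatic ring of the amide.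

Compound 3 `COc1ccc2nc(C)cc(OCC(=O)NCCCc3ccccc3)c2c1` differs from compound 2 in that (3-phenylpropyl in place of 4-methylphenyl on an amide-type nitrogen). For the measured compounds named here, no measured step touches this position, and the one step known exchanges ring substituents rather than the whole group on the amide nitrogen, so it cannot be carried over. For compound 3 the expectation in this assay is therefore a step of no more than a 1.2-fold higher number from compound 2 to compound 3 (0.08 log units; within the scatter) from compound 2, with wide uncertainty. The estimate for compound 3 in this assay is 50000 nM, expected between 15000 nM and 150000 nM.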

Compound 3, half-maximal cytotoxic concentration: 50700 nM
Beside the measured number, compound 3's estimate is 1.0-fold (0.01 log units) below it, and the stated range covers the measured number.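

Exchanging 4-methylphenyl for 3-phenylpropyl on the amide-type nitrogen gives a 1.2-fold higher number from compound 2 to compound 3 (0.09 log units; within the scatter) in this assay, so the whole group at this position can change without the two compounds being told apart, whereas the earlier step only exchanged a ring substituent. The exchange of 4-methoxyphenyl for 3-phenylpropyl gives an at least 2.8-fold lower number from compound 1 to compound 3 (0.44 log units; beyond the scatter), so compound 1 now stands apart from both compound 2 and compound 3. The value of compound 1 is a limit, and this second step rests on it: the limit of > 142000 nM in this assay, at which 1 of the 3 values shown sits.

Still open, from the compounds shown here alone, is whether a shorter chain such as benzyl, or a chain ending in an amine or a carboxylic acid, stays level with compound 2 and compound 3. Also open, going by these compounds, is whether a methoxy group on the phenyl ring of 3-phenylpropyl would give the same step as on the 4-methylphenyl series.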